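A few compounds are considered here, and "the series" means these few. Any claim that something is new, unique, unknown or untested is made for them only; others in the source may bear on it.

Working notes on the series built on the shared core of compound 1 `CCc1cccc2c(OC)c(-c3occ(C)c3C(=O)OC)ccc12`, which in a functional assay on DU-145 cells (Homo sapiens) for cytotoxicity, read by MTT assay, with a stated time of 72 h (on this read-out higher numbers stand for an effect only at larger amounts of compound and lower numbers for an effect already at smaller amounts), gives 2.2 ug/mL. Compound 2 `CCCOC(=O)c1c(C)coc1-c1ccc2c(CC)cccc2c1OC` in this assay reaches only the limit > 10 ug/mL. Compound 3 `CCc1cccc2c(OC)c(-c3occ(C)c3C(=S)OC)ccc12` gives 5.7 ug/mL in this assay. Of the two numbers shown, compound 3 stands highest; its nearest neighbour is compound 1, the two being separated by a 2.6-fold higher number from compound 1 to compound 3 (0.41 log units; beyond the scatter). The other measured step on the same ring carbon, an at least 4.5-fold higher number from compound 1 to compound 2 (0.65 log units; beyond the scatter), also went toward a higher number, and the pair of compound 2 and compound 3 shows an at least 1.7-fold lower number from compound 2 to compound 3 (0.24 log units; that floor lies within the scatter), which rests on the limit (the limit of > 10 ug/mL in this assay, at which 1 of the 3 values shown sits).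

The next compound, compound 4 `CCc1cccc2c(OC)c(-c3occ(C)c3COC)ccc12`, differs from compound 3 by a group of 3 heavy atoms (2 carbon, 1 oxygen; no ring) in place of a group of 4 heavy atoms (2 carbon, 1 oxygen, 1 sulfur; no ring), on an aromatic carbon. Among the compounds with values here, no measured step removes the thiocarbonyl from this ring carbon, so the bearing of the earlier steps is indirect: both changes made so far at this carbon, a 2.6-fold higher number from compound 1 to compound 3 (0.41 log units; beyond the scatter) and an at least 4.5-fold higher number from compound 1 to compound 2 (0.65 log units; beyond the scatter), raised the number. A further rise, of modest size and possibly ending at a limit, is therefore expected for compound 4, a 1.4-fold higher number from compound 3 to compound 4 (0.15 log units; within the scatter). Compound 4 is estimated at 8 ug/mL, within 3 ug/mL to 20 ug/mL.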

Compound 4, concentration for half-maximal effect: > 10 ug/mL
Compound 4 gave a limit, no number (the forecaster's own chance of this, stated with the estimate: 35%); middle value at least 1.2-fold (0.09 log units) from the limit.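

With methoxymethyl in place of methoxycarbonyl on this ring carbon, the carbonyl is gone altogether, and this assay gives an at least 4.5-fold higher number from compound 1 to compound 4 (0.65 log units; beyond the scatter), so all three changes made to the ester of compound 1 at this carbon now go the same way, with no compound shown going against it. Set against the thiocarbonyl compound, the same replacement gives an at least 1.7-fold higher number from compound 3 to compound 4 (0.24 log units; that floor lies within the scatter), so compound 4 cannot yet be separated from compound 3, and the loss relative to compound 1 is the only firm reading of this change. Compound 2 and compound 4 each end at a limit and not at a number, so the step between them cannot be read: the limit of > 10 ug/mL in this assay, at which 2 of the 4 values shown sit.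

Going by these compounds, how far compound 2 and compound 4 lie past that limit stays open, and with it any ranking of the propoxycarbonyl and methoxymethyl groups. Also open is whether an ethoxycarbonyl group, a primary amide, a carboxylic acid or a hydroxymethyl group on this ring carbon would stay close to compound 1 at 2.2 ug/mL or fall away as the changes shown here do.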